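Sulfonamide series: benzoxazole sulfonamides against mitochondrial malate dehydrogenase

The compounds below may be only part of what the source reports. "The series", "measured", "known", "first", "only" and "open" are said of these compounds alone.

Two members of the series have been tested in an assay on isolated protein for inhibition of malate dehydrogenase, mitochondrial (Sus scrofa), with stated times of 45 min and 30 min (on this read-out higher numbers stand for weaker inhibition and lower numbers for stronger inhibition), and both returned only a limit. Compound 1 `O=S(=O)(Nc1ccc2oc(-c3ccccc3)nc2c1)c1cccc(C(F)(F)F)c1` stands at the limit in this assay, reported as > 63000 nM. Compound 2 `O=S(=O)(Nc1ccc(-c2nc3ccccc3o2)cc1)c1ccc(Cl)s1` likewise reaches only the limit, reported as > 63000 nM. Among the compounds with values here, both values sit at the limit of > 63000 nM in this assay, at which 2 of the 2 values shown sit, so no step between measured compounds can be given and no trend is visible. Compound 3 `Cc1cccc(S(=O)(=O)Nc2ccc(-c3nc4ccccc4o3)cc2)c1` is not yet measured. It differs from compound 2 in one place: 3-methylphenyl in place of 5-chlorothiophen-2-yl on a sulfonyl sulfur. With both known values resting on the limit, there is no ground for expecting a step beyond the usual scatter in either direction; the expected change from compound 2 is a step that the limit leaves unreadable from compound 2 to compound 3, most likely again a limit rather than a number. Compound 3 is therefore estimated at 80000 nM in this assay, with a range from 30000 nM to 300000 nM.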

Compound 3, half-maximal inhibitory concentration: > 63000 nM
Compound 3 was reported as a limit; the forecaster's own chance of this, stated with the estimate: 85%; the middle value lies beyond the limit too.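

No step can be read from compound 2 to compound 3, because both stand only as limits: the limit of > 63000 nM in this assay, at which 3 of the 3 values shown sit. The compounds shown leave open whether any member of the series gives a readable number in this assay, and whether the group on the sulfonyl sulfur matters there.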